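Aryl swap on the shared core, both anchors at the limit

The compounds below may be only part of what the source reports. "The series", "measured", "known", "first", "only" and "open" are said of these compounds alone.

compound 1 `O=c1[nH]cnc2c1c(-c1cccs1)cn2[C@@H]1O[C@H](CO)[C@@H](O)[C@H]1O`: > 20000 nM
compound 2 `Nc1nc2c(c(-c3cccs3)cn2[C@@H]2O[C@H](CO)[C@@H](O)[C@H]2O)c(=O)[nH]1`: > 20000 nM
compound 3 `O=c1[nH]cnc2c1c(-c1ccccc1)cn2[C@@H]1O[C@H](CO)[C@@H](O)[C@H]1O`: not yet measured

In a functional assay on A549 cells (Homo sapiens), read by MTT assay, with a stated time of 72 h (on this read-out higher numbers stand for weaker inhibition and lower numbers for stronger inhibition), compound 1 gives > 20000 nM, which is a limit of the assay and not a number. In this assay compound 2 gives > 20000 nM, again a limit. Compound 1 thus stands at the limit, with no number of its own. For the measured compounds named here, the only measured step is a step that the two limits leave unreadable from compound 1 to compound 2, and it stays unreadable because both of its ends sit at the limit of > 20000 nM in this assay, at which 2 of the 2 values shown sit. The change from compound 1 to compound 3 is phenyl in place of thiophen-2-yl on an aromatic carbon. Going by the values given here, no measured step bears on this change, since the single step known here concerns an amino group rather than the aryl ring. Compound 3 is expected to give 30000 nM, within a range of 12000 nM to 100000 nM, most probably reported again as a limit. The step that the limit leaves unreadable from compound 1 to compound 3 that this estimate means is expected to be none beyond the scatter.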

Compound 3, half-maximal inhibitory concentration: > 100000 nM
Compound 3 was reported as a limit (the forecaster's own chance of this, stated with the estimate: 80%); middle value at least 3.3-fold (0.52 log units) from the limit.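

Compound 1 and compound 3 are both reported as limits of the assay in this assay, and the step between them cannot be read. The compounds shown leave open how phenyl and thiophen-2-yl compare on the shared core, and whether either gives a numerical value.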